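The source may hold more compounds than are shown below. What is called first, only, known or untested is meant among the compounds shown, and "the series" means these compounds.

Series notes. All three measured compounds share the core of compound 1 `CC(C)[C@H](NC(=O)COc1cccc2ccccc12)C(=O)N[C@@H](CC(=O)O)C(=O)COc1ccc2ccccc2c1` and differ only in the aryl group on an oxygen on a saturated carbon. In a functional assay with Homo sapiens as the target (a lower number here means a stronger inhibitor, a higher number a weaker inhibitor), compound 1 gives 15900 nM, the highest of the three numbers, though neither neighbour lies outside the scatter: compound 2 `CC(C)[C@H](NC(=O)COc1cccc2ccccc12)C(=O)N[C@@H](CC(=O)O)C(=O)COc1ccc(C(F)(F)F)cc1` gives 12300 nM and compound 3 `CC(C)[C@H](NC(=O)COc1cccc2ccccc12)C(=O)N[C@@H](CC(=O)O)C(=O)COc1c(Cl)cccc1Cl` gives 15300 nM. The moves are a 1.3-fold lower number from compound 1 to compound 2 (0.11 log units; within the scatter), a 1.0-fold lower number from compound 1 to compound 3 (0.02 log units; within the scatter) and a 1.2-fold higher number from compound 2 to compound 3 (0.09 log units; within the scatter), so across the three aryl groups tried this assay has not separated them.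

Compound 4 `CC(C)[C@H](NC(=O)COc1cccc2ccccc12)C(=O)N[C@@H](CC(=O)O)C(=O)COc1ccc([N+](=O)[O-])cc1F` carries 2-fluoro-4-nitrophenyl in place of naphthalen-2-yl on an oxygen on a saturated carbon. The three measured steps all bear on it directly, as each exchanges the same aryl group at the same place; none of them exceeded the scatter, and a group carrying a nitro and a fluorine has not been tried, so nothing further can be drawn from the data. The expectation is therefore a step of no size beyond the scatter, a 1.1-fold lower number from compound 1 to compound 4 (0.03 log units; within the scatter). Compound 4 is estimated at 15000 nM in this assay, with a range from 7000 nM to 32000 nM; the range is kept wide as the new group lies outside those measured.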

Compound 4, half-maximal inhibitory concentration: 15800 nM
Compound 4: the middle estimate sits 1.1-fold (0.02 log units) below what was measured; measured number inside the range.
By their numbers in this assay, from the lowest: compounds 2, 3, 4 and 1 (each within the scatter of the next).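

The new group differs from the earlier three in make-up, and this assay still does not separate it from them: the steps are a 1.0-fold lower number from compound 1 to compound 4 (0.00 log units; within the scatter) and a 1.0-fold higher number from compound 3 to compound 4 (0.01 log units; within the scatter) and also a 1.3-fold higher number from compound 2 to compound 4 (0.11 log units; within the scatter) so all four aryl groups at this position remain within the scatter of one another. The change from compound 1 to compound 4 replaces two six-membered aromatic rings of carbon with one, brings in a nitro group and a fluorine, and takes the count of hydrogen-bond acceptors in the group from 0 to 2, yet none of this registers as a step beyond the scatter. No measurement on these compounds offers an explanation for this flat response.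

As far as these compounds go, it remains open whether this position would respond to a group that is not an aryl ether at all, such as a saturated alkyl chain, an amine or a carboxylic acid on the aryl ring. Also open, from the compounds shown here alone, is whether any change elsewhere on the shared core would move the number more than the exchanges of aryl group have done so far.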